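This account rests on a few compounds, and the source may have more. Where it says the series, first, only, none or still open, it means among the compounds named here.

Compound 2 `Nc1ccccc1NC(=O)c1ccc(CNC(=O)c2n[nH]cc2NC(=O)c2ccccc2F)cc1` stands at the higher of the two numbers in a functional assay on HCT-116 cells (Homo sapiens) for inhibition, read by CCK-8 assay, with a stated time of 72 h (on this read-out higher numbers stand for weaker inhibition and lower numbers for stronger inhibition), where compound 2 gives 4800 nM. Compound 1 `O=C(NO)c1ccc(CNC(=O)c2n[nH]cc2NC(=O)c2ccccc2Cl)cc1` gives 2400 nM in this assay, a gap that lies within the usual scatter. Compound 3 `Nc1ccccc1NC(=O)c1ccc(CNC(=O)c2n[nH]cc2NC(=O)c2ccccc2)cc1` has not yet been measured; it differs from compound 2 by hydrogen in place of fluoro on an aromatic carbon. Within the data shown here, no measured step of this kind is available, so the expectation rests on the two values alone. A step of no more than the scatter is expected, in no clear direction. Compound 3 is estimated to give 5500 nM in this assay, with a range of 2000 nM to 15000 nM, which means an expected step of a 1.1-fold higher number from compound 2 to compound 3 (0.06 log units; within the scatter).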

Compound 3, half-maximal inhibitory concentration: 1660 nM
Compound 3: the middle estimate sits 3.3-fold (0.52 log units) above what was measured; measured number below the stated range.
By their numbers in this assay, from the lowest: compounds 3, 1 and 2 (each within the scatter of the next, the first and the last beyond it).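

In this assay the change from 2-fluorophenyl to phenyl gives a 2.9-fold lower number from compound 2 to compound 3 (0.46 log units; beyond the scatter) and so provides the first step beyond the scatter for a single change among these compounds. At this aromatic carbon the fluoro is therefore not needed for the inhibition read here, and hydrogen serves better in this pair. Nothing measured here accounts for the step.

Going by these compounds, whether a methoxy group or an amine at the same aromatic carbon would match hydrogen or fluoro remains open. A single pair also cannot show whether the step holds on other versions of the shared core.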